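The source may hold more compounds than are shown below. What is called first, only, known or untested is meant among the compounds shown, and "the series" means these compounds.

Of the compounds shown here, three have values so far in a functional assay on the whole organism for antagonist activity, with Mus musculus as the target (on this read-out higher numbers stand for an effect only at larger amounts of compound and lower numbers for an effect already at smaller amounts), as follows.

- compound 1 (`CCC(=O)N(c1ccc(OC)cc1)C1CCCC1N(C)C`) gives 20 mg/kg; 20 mg/kg (2 entries) in both entries
- compound 2 (`CCC(=O)N(c1cccc(C)c1)C1CCCC1N(C)C`) gives 1 mg/kg; 1 mg/kg (2 entries) in both entries
- compound 3 (`CCC(=O)N(c1cccc(OC)c1)C1CCCC1N(C)C`) gives 4 mg/kg as its only number

Two further entries for compound 3 come without a single number. The dose for compound 3 is larger than that of compound 2 at 1 mg/kg; 1 mg/kg (2 entries) and smaller than that of compound 1 at 20 mg/kg; 20 mg/kg (2 entries) in this series.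

Compound 4 (`CCC(=O)N(c1ccc(OC)c(OC)c1)C1CCCC1N(C)C`) has yet to be measured. It puts methoxy in place of hydrogen on an aromatic carbon, ortho to a methoxy group and para to a large group (methoxy in place of hydrogen on an aromatic carbon). Among the measured compounds shown here, no measured pair shows a single change of this kind, so the expectation rests on the values alone. The nearest guide is compound 1, which carries methoxy para to a large group and gives 20 mg/kg; 20 mg/kg (2 entries) in this assay as its dose. A shift towards a larger dose is therefore expected, and the estimate is a 3.0-fold higher number from compound 3 to compound 4 (0.48 log units; beyond the scatter) with wide uncertainty. In this assay the expected value for compound 4 is 12 mg/kg with 4 mg/kg to 40 mg/kg as its estimated range.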

Compound 4, dose for half-maximal effect: 10 mg/kg
Compound 4: the middle estimate sits 1.2-fold (0.08 log units) above what was measured, within the range that was stated.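

In this assay, among the compounds shown here, the change from hydrogen to methoxy on the aromatic carbon para to a large group and ortho to a methoxy group gives the first single-change comparison: a 2.5-fold higher number from compound 3 to compound 4 (0.40 log units; beyond the scatter). It shows that this position accepts the added methoxy with activity retained, but that in this one pair the added group goes with a need for a larger dose. No measurement at hand accounts for the shift, so the data give its size and direction but not its origin.

The compounds shown leave open whether a different group in this place, such as a fluorine atom, a hydroxyl or an amine, would move the dose in the same direction as methoxy, or by as much. They also leave open whether methoxy in the same place would carry a similar step on compound 2, which gives 1 mg/kg; 1 mg/kg (2 entries) and carries methyl where compound 3 carries methoxy.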